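Glucagon receptor antagonists: chain extension at the benzylic carbon

A few compounds are considered here, and "the series" means these few. Any claim that something is new, unique, unknown or untested is made for them only; others in the source may bear on it.

Measured compounds:
compound 1 `CCC[C@H](c1ccc(C(=O)NCc2nn[nH]n2)cc1)N1C(=O)C(c2cc(Cl)cc(Cl)c2)=N[C@]12CC[C@@H](C(C)(C)C)CC2`: 220 nM
compound 2 `CC(C)(C)[C@H]1CC[C@]2(CC1)N=C(c1cccc(Cl)c1)C(=O)N2Cc1ccc(C(=O)NCCC(=O)O)cc1`: 770 nM
compound 3 `CC(C)(C)CC[C@H](c1ccc(C(=O)NCCS(=O)(=O)O)cc1)N1C(=O)C(c2cc(Cl)cc(Cl)c2)=N[C@]12CC[C@@H](C(C)(C)C)CC2`: 8500 nM

In a functional assay on CHO cells for antagonist activity at Glucagon receptor (Homo sapiens), read by cAMP accumulation, with stated times of 30 min and 45 min (a lower number here means a stronger inhibitor, a higher number a weaker inhibitor), compound 1 gives the lowest of the three numbers. Compound 2 gives a higher number than compound 1, a gap beyond the scatter; compound 3 gives a much higher number still. Compound 2 and compound 3 each differ from compound 1 in several places at once, so no single change can be read out of those gaps.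

Compound 4 `CC1(CC[C@H](c2ccc(C(=O)NCc3nn[nH]n3)cc2)N2C(=O)C(c3cc(Cl)cc(Cl)c3)=N[C@]23CC[C@@H](C(C)(C)C)CC3)CC1` is not yet measured. It carries 1-methylcyclopropyl in place of methyl on a saturated chain carbon, three bonds along the chain from an amide-type nitrogen in a ring and an aromatic carbon. The chain keeps its length from the amide-type nitrogen in the ring and the aromatic carbon; only the terminal group on it grows. Among the compounds with values here, nothing among the measured compounds isolates this kind of change, and the one compound with a bulkier chain, compound 3, also carries a different acid group, so its number cannot be used for this step.

For compound 4 a step from compound 1 that stays within the scatter, or at most a modest move to a weaker number, is expected, a 1.4-fold higher number from compound 1 to compound 4 (0.13 log units; within the scatter). Compound 4 is estimated at 300 nM in this assay, with a range from 90 nM to 1000 nM.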

Compound 4, half-maximal inhibitory concentration: 100 nM
The estimate for compound 4 lay 3.0-fold (0.48 log units) above the measured number; the measured number falls inside the stated range.
By their numbers in this assay, from the lowest: compound 4; then compound 1; then compound 2; then compound 3.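

In this assay, within the data shown here, the change from methyl to 1-methylcyclopropyl gives a 2.2-fold lower number from compound 1 to compound 4 (0.34 log units; beyond the scatter), the first step that can be read at a single place. The position, on a saturated chain carbon, three bonds along the chain from an amide-type nitrogen in a ring and an aromatic carbon, therefore tolerates the larger terminal group in this read-out, with a modest gain rather than a loss. Nothing at hand explains the step.

Still open, going by these compounds, is whether the gain depends on the three-membered ring, which a tert-butyl group or a plain cyclopropyl at the same place would help to separate. Also open, on these data alone, is whether the same change holds with a carboxylic acid, as in compound 2, or a sulfonic acid, as in compound 3.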